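This account rests on a few compounds, and the source may have more. Where it says the series, first, only, none or still open, it means among the compounds named here.

Measured compounds:
Compound 1 `O=C(/C=C\Nc1ccc(C(F)(F)F)cc1)c1cn(-c2ccccc2)nc1-c1ccccc1`: in an ADME assay on HaCaT cells (Homo sapiens) for antiproliferative activity, read by MTT assay, with a stated time of 48 h (a higher number here means a weaker inhibitor, a lower number a stronger inhibitor), compound 1 gives > 50000 nM, which is a limit of the assay and not a number (the limit of > 50000 nM in this assay, at which 1 of the 3 values shown sits).
Compound 2 `COc1ccc(-c2nn(-c3ccccc3)cc2C(=O)/C=C\Nc2ccc(F)cc2)cc1`: compound 2 gives 8910 nM.
Compound 3 `COc1cc(-c2nn(-c3ccccc3)cc2C(=O)/C=C\Nc2ccc(Cl)cc2)cc(OC)c1OC`: compound 3 gives 30200 nM.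

Of the two numbers shown, compound 3 holds the higher one; the nearest, that of compound 2, lies lower by a margin beyond the usual scatter. Compound 4 `COc1cc(-c2nn(-c3ccccc3)cc2C(=O)/C=C\Nc2ccc(O)cc2)cc(OC)c1OC` differs from compound 3 by hydroxy in place of chloro on an aromatic carbon. Among the compounds with values here, no measured pair shows this change, so its size here is unknown. The expectation for compound 4 is a step of a 1.3-fold higher number from compound 3 to compound 4 (0.12 log units; within the scatter) that stays near the scatter, leaning toward a higher number. Compound 4 is expected at 40000 nM, with a range from 12000 nM to 50000 nM.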

Compound 4, half-maximal inhibitory concentration: 17600 nM
Compound 4: the middle estimate sits 2.3-fold (0.36 log units) above what was measured; the range from low to high includes it.
By their numbers in this assay, from the lowest: compounds 2, 4 and 3 (each within the scatter of the next, the first and the last beyond it). At a limit, above all of these: compound 1.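

In this assay, hydroxy in place of chloro on an aromatic carbon, para to a large group, gives a 1.7-fold lower number from compound 3 to compound 4 (0.23 log units; within the scatter). Within the data shown here, this is the first measured change at this position, and it shows that exchanging chloro for hydroxy, which brings in a hydrogen-bond donor and acceptor, stays within the scatter on this core. Nothing measured here bears on the reason for this step.

As far as these compounds go, what an amine or a carboxylic acid would give at this position stays open. So does whether the same exchange behaves alike with the other aryl groups on the shared core.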